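From hydroxy to carbamoyl: compound 1 and compound 4

The compounds below may be only part of what the source reports. "The series", "measured", "known", "first", "only" and "open" are said of these compounds alone.

Values measured in a functional assay on HCT-116 cells (Homo sapiens) for inhibition, read by sulforhodamine B assay, with a stated time of 48 h, tested at 50 uM (on this read-out higher numbers stand for more inhibition of growth at the one concentration tested and lower numbers for less inhibition of growth), are:
- compound 1 `COc1ccc([C@@H]2C/C(=N/OCc3cn(-c4ccc(O)cc4)nn3)c3cc(CC=C(C)C)c(OC)cc3O2)cc1` gives 65%
- compound 2 `COc1cc2c(cc1CC=C(C)C)C(=O)C[C@@H](c1ccc(Oc3ccc(F)cc3)cc1)O2` gives 29%
- compound 3 `COc1cc2c(cc1CC=C(C)C)/C(=N/O)C[C@@H](c1ccc(O)cc1)O2` gives 99%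

Compound 1 stands second highest of the three at 65% with compound 3 higher and compound 2 lower, each gap beyond the scatter. Compound 4 `COc1ccc([C@@H]2C/C(=N/OCc3cn(-c4ccc(C(N)=O)cc4)nn3)c3cc(CC=C(C)C)c(OC)cc3O2)cc1` differs from compound 1 in one place, 4-hydroxyphenyl to 4-carbamoylphenyl, with carbamoyl in place of hydroxy on an aromatic carbon. Within the data shown here, no measured pair shows this change, so the expectation in this assay rests only on compound 1 at 65% and stays wide. A small fall, within the scatter, is expected (a number 7 percentage points lower from compound 1 to compound 4 (within the scatter)). For compound 4 the estimated value is 58% (expected range 35% to 80%).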

Compound 4, percent growth inhibition at one concentration: 100%
Compound 4: the middle estimate sits 42 percentage points below what was measured; the whole stated range lies below it.
By their numbers in this assay, from the lowest: compound 2; then compound 1; then compounds 3 and 4 (each within the scatter of the next).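

The aromatic carbon carrying the 4-hydroxyphenyl substituent's hydroxy group proves to be a sensitive position: in this assay, carbamoyl in place of hydroxy gives a number 35 percentage points higher from compound 1 to compound 4 (beyond the scatter). This single change on the shared core is enough to move growth inhibition at the one concentration tested well past the scatter. Nothing available accounts for the size of this step.

Open, from the compounds shown here alone, is whether a carboxylic acid, an amine or a methyl ester at the same place would match compound 4 at 100%. Also open, going by these compounds, is whether this step holds on other cores, since it rests on one pair.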